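This account rests on a few compounds, and the source may have more. Where it says the series, first, only, none or still open, it means among the compounds named here.

In a functional assay on Jurkat cells (Homo sapiens) for inhibition, read by MTT assay, with a stated time of 72 h (a lower number here means a stronger inhibitor, a higher number a weaker inhibitor), compound 2 (`CO[C@@H](c1ccccc1)[C@H]1O[C@@H]2CC(=O)O[C@@H]2[C@H]1O`) gives 12600 nM and compound 1 (`CO[C@@H]1[C@H]2OC(=O)C[C@H]2O[C@@H]1[C@@H](O)c1ccccc1`) gives 15500 nM and these two values lie within the scatter of each other. Compound 3 (`CO[C@@H]1[C@H]2OC(=O)C[C@H]2O[C@@H]1[C@@H](OC)c1ccccc1`) differs from compound 2 by one change (methyl in place of hydrogen on an oxygen on a saturated carbon), with methyl in place of hydrogen on an oxygen on a saturated carbon, so hydroxy becomes methoxy. Among the measured compounds shown here, the series holds no measured step of this kind to draw on. An estimated step of a 1.0-fold higher number from compound 2 to compound 3 (0.01 log units; within the scatter) is expected to stay within the scatter, with no direction claimed. In this assay compound 3 is estimated at 13000 nM (range 6000 nM to 30000 nM).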

Compound 3, half-maximal inhibitory concentration: 1690 nM
Estimate against measurement, compound 3: 7.7-fold (0.89 log units) above; measured number below the stated range.
By their numbers in this assay, from the lowest: compound 3; then compounds 2 and 1 (each within the scatter of the next).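

In this assay the change from hydroxy to methoxy gives a 7.5-fold lower number from compound 2 to compound 3 (0.87 log units; beyond the scatter) and also a 9.2-fold lower number from compound 1 to compound 3 (0.96 log units; beyond the scatter), so the same change at either of the two oxygens lowers the number beyond the scatter. Compound 3 is the only one of the three with no free hydroxy, and compound 1 and compound 2 each keep one. Nothing measured here explains these steps.

From the compounds shown here alone, whether a longer chain such as ethyl or an acetate ester on these oxygens keeps the lower number remains open. So does whether an amine there would be tolerated.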